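The source may hold more compounds than are shown below. What is called first, only, known or untested is meant among the compounds shown, and "the series" means these compounds.

Working notes on a three-membered set that shares one core and was tested in a functional assay on SK-BR-3 cells (Homo sapiens) for inhibition, read by MTT assay, with a stated time of 2 days, tested at 10 uM; a lower number here means less inhibition of growth, a higher number more inhibition of growth at the concentration tested. Compound 1 `CNC(=O)c1cc(Oc2ccc3nc(NC(=O)Nc4ccc(Cl)cc4Cl)sc3c2)ccn1` gives 22.3%. Compound 2 `CNC(=O)c1cc(Oc2ccc3nc(NC(=O)Nc4ccc(Br)cc4)sc3c2)ccn1` gives 26.7%. Compound 3 `CNC(=O)c1cc(Oc2ccc3nc(NC(=O)c4cc(Cl)cc(Cl)c4)sc3c2)ccn1` gives 9.62%, the lowest of the three numbers; its nearest neighbour is compound 1 and its furthest is compound 2. The step of a number 12.7 percentage points lower from compound 1 to compound 3 (beyond the scatter) and the step of a number 17.1 percentage points lower from compound 2 to compound 3 (beyond the scatter) both put a dichlorophenyl group on the carbonyl carbon in place of an arylamino group, and both fall beyond the scatter. The step of a number 4.4 percentage points higher from compound 1 to compound 2 (within the scatter) exchanges one halogenated phenyl for another on an amide-type nitrogen and stays within the scatter.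

Compound 4 `CNC(=O)c1cc(Oc2ccc3nc(NC(=O)c4ccc(Cl)cc4Cl)sc3c2)ccn1` is not yet measured. It differs from compound 3 by 2,4-dichlorophenyl in place of 3,5-dichlorophenyl on a carbonyl carbon. Within the data shown here, no measured step exchanges one dichlorophenyl for another on a carbonyl carbon; the nearest analogy in the set is the exchange of halogenated phenyl groups on the amide-type nitrogen, which stayed within the scatter. On that basis the expected step of a number 1.4 percentage points higher from compound 3 to compound 4 (within the scatter) is none beyond the scatter, in either direction. Compound 4 is therefore estimated at 11%, with a range from 0% to 24%.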

Compound 4, percent growth inhibition at one concentration: 14%
Compound 4: middle estimate off by 3 percentage points, on the low side; measured number inside the range.
By their numbers in this assay, from the lowest: compounds 3, 4, 1 and 2 (each within the scatter of the next, the first and the last beyond it).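

Among these compounds, the step of a number 4.4 percentage points higher from compound 3 to compound 4 (within the scatter) is the first exchange of one dichlorophenyl for another on the carbonyl carbon, and it shows that 2,4-dichlorophenyl and 3,5-dichlorophenyl are not told apart at this position. Among the compounds shown here, with 2,4-dichlorophenyl on the carbonyl carbon, the step of a number 8.3 percentage points lower from compound 1 to compound 4 (within the scatter) gives the first comparison in which the same aryl group stands with and without the amino nitrogen, and it stays within the scatter. The step of a number 12.7 percentage points lower from compound 2 to compound 4 (beyond the scatter) is beyond the scatter, so arylamino groups give higher numbers than directly attached dichlorophenyl groups in three of the four such steps, with the step to compound 4 from compound 1 going against that pattern.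

No measurement at hand accounts for these steps. The compounds shown leave open how an amine or a carboxylic acid on the phenyl ring, or a longer chain on the carbonyl carbon, would change the number.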